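This account rests on a few compounds, and the source may have more. Where it says the series, first, only, none or still open, it means among the compounds named here.

Measured so far:
- compound 1, `CCCCn1nc2oc(=O)cc(C)c2c1C`: > 100 mg/kg
- compound 2, `Cc1cc(=O)oc2c1c(C)nn2C`: 11.6 mg/kg

Both compounds were tested in a functional assay on the whole organism with Mus musculus as the target, in the writhing test; on this read-out higher numbers stand for an effect only at larger amounts of compound and lower numbers for an effect already at smaller amounts. In this assay compound 2 gives 11.6 mg/kg. For compound 1 the result is a limit of the assay and not a number: compound 1 gives > 100 mg/kg, meaning that no half-maximal effect was reached within the doses tested. Where compound 1 stands is therefore only known as the limit of > 100 mg/kg in this assay, at which 1 of the 2 values shown sits. Among the compounds with values here, the two values cannot be set side by side as a measured step; they show only that compound 2 produced an effect at a dose where compound 1 was still without a measured effect.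

The next compound, compound 3, `CCn1nc2oc(=O)cc(C)c2c1C`, differs from compound 1 in one place: hydrogen in place of ethyl on a saturated chain carbon, two bonds along the chain from an aromatic nitrogen. The shared core is kept; only the chain on the aromatic nitrogen is shortened.

For compound 1 only a limit of the assay is known. Compound 2, in turn, gives 11.6 mg/kg. On this basis the step is expected to move toward lower numbers, by about an at least 3.3-fold lower number from compound 1 to compound 3 (0.52 log units; beyond the scatter). The dose for compound 3 in this assay is estimated at 30 mg/kg, with a range from 12 mg/kg to 100 mg/kg.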

Compound 3, dose for half-maximal effect: 14.6 mg/kg
Estimate against measurement, compound 3: 2.1-fold (0.31 log units) above; measured number inside the range.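

In this assay, cutting the butyl chain on the aromatic nitrogen back to ethyl gives an at least 6.8-fold lower number from compound 1 to compound 3 (0.83 log units; beyond the scatter), so with the shared core unchanged, the length of this chain matters. The earlier pair showed only the butyl and methyl ends of the series, whereas the new result shows that an ethyl chain also gives a measurable effect: compound 3 gives 14.6 mg/kg, and compound 2, with methyl, gives 11.6 mg/kg. The true size of the step from butyl to ethyl may be larger than the printed figure, since the value of compound 1 is a limit of the assay and not a number: the limit of > 100 mg/kg in this assay, at which 1 of the 3 values shown sits.

Going by these compounds, it remains open how a propyl chain on the same nitrogen would behave, and so at what chain length the measured effect gives way to the limit seen with butyl. On these data alone, it is equally open whether a branched isopropyl group, or an amine at the end of the chain, would keep the effect, and these whole-animal doses alone cannot explain why the butyl compound falls short.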